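Aryl variation on the ring amine: notes toward compound 4

The compounds below may be only part of what the source reports. "The series", "measured", "known", "first", "only" and "open" are said of these compounds alone.

The three measured compounds share one core and differ only in the aryl group on an amine nitrogen in a ring of a six-membered non-aromatic ring with 2 nitrogen. In an assay on CHO cells for displacement of a labelled ligand from adenosine receptor A1 (Homo sapiens), read by scintillation counting, with a stated time of 120 min, tested at 10 uM (on this read-out lower numbers stand for less inhibition and higher numbers for more inhibition at the one concentration tested (going by the name of the read-out)), compound 1 `Nc1scc(CN2CCN(c3ccc(Cl)cc3Cl)CC2)c1C(=O)c1ccc(Cl)cc1` gives 0%. Compound 2 `Nc1scc(CN2CCN(c3cccc(Cl)c3Cl)CC2)c1C(=O)c1ccc(Cl)cc1` gives 2% in this assay, and compound 3 `Nc1scc(CN2CCN(c3ccc(F)cc3Cl)CC2)c1C(=O)c1ccc(Cl)cc1` gives 0%. The steps between them are all small: a number 2 percentage points higher from compound 1 to compound 2 (within the scatter), no change at the digits printed from compound 1 to compound 3 (within the scatter) and a number 2 percentage points lower from compound 2 to compound 3 (within the scatter). Compound 3 therefore sits with compound 1 and compound 2 in a single cluster of numbers near the floor of the read-out, with no separation beyond the scatter among the three.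

Compound 4 `Nc1scc(CN2CCN(c3ccccc3C(F)(F)F)CC2)c1C(=O)c1ccc(Cl)cc1` differs from compound 3 in 2-(trifluoromethyl)phenyl in place of 2-chloro-4-fluorophenyl on an amine nitrogen in a ring. Every measured step in this set is a change of the aryl group on the same ring nitrogen, and none of them moved this assay beyond the scatter, so the same kind of change is expected to leave the read-out where it is. The step from compound 3 to compound 4 is estimated as a number 1 percentage points higher from compound 3 to compound 4 (within the scatter), that is, no movement beyond the scatter. Compound 4 is accordingly expected to give 1% in this assay, with a range from -8% to 10%.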

Compound 4, a percentage reported as inhibition, at one concentration (the size of the read-out at that concentration, not a potency): 0%
Compound 4: the middle estimate sits 1 percentage points above what was measured; the range from low to high includes it.
By their numbers in this assay, from the lowest: compounds 1, 3, 4 and 2 (each within the scatter of the next).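

In this assay the change to the new aryl group reads as no change at the digits printed from compound 3 to compound 4 (within the scatter) and the two further steps read as a number 2 percentage points lower from compound 2 to compound 4 (within the scatter) and no change at the digits printed from compound 1 to compound 4 (within the scatter) on this ring nitrogen. The three earlier aryl groups all carry chlorine, whereas 2-(trifluoromethyl)phenyl carries none and has 10 heavy atoms against the 8 of 2-chloro-4-fluorophenyl, so removing chlorine from this position and enlarging the group still leaves all four compounds in one cluster near the floor of the read-out. No supporting measurement is available to explain this flat result.

With every value in this set near the floor, the compounds shown leave open whether any change on this ring nitrogen can lift the read-out at all. As far as these compounds go, it also remains open whether an amine or a carboxylic acid on the aryl group, or a longer chain in place of that group, would separate from this cluster beyond the scatter.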